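Notes on the phenyl to 4-chlorophenyl step

The compounds below may be only part of what the source reports. "The series", "measured", "known", "first", "only" and "open" are said of these compounds alone.

Measured so far in an ADME assay on HEK293 cells (Homo sapiens) for cytotoxicity, read by MTT assay, with a stated time of 48 h; on this read-out higher numbers stand for weaker inhibition and lower numbers for stronger inhibition
compound 1 `O=C1CS/C(=N/c2ccccc2)N1Cc1ccncc1` gives 99500 nM
compound 2 `O=C1/C(=C\c2ccccc2)S/C(=N/c2ccccc2)N1Cc1ccncc1` gives 64700 nM

Compound 2 (64700 nM) lies within the usual scatter of compound 1 (99500 nM). Compound 3 `O=C1/C(=C\c2ccc(Cl)cc2)S/C(=N/c2ccccc2)N1Cc1ccncc1` has chloro in place of hydrogen on an aromatic carbon of compound 2 chloro in place of hydrogen on an aromatic carbon and so turns phenyl into 4-chlorophenyl. Within the data shown here, no measured pair differs in one place, so the data offer no direct guide to this change. The estimated 1.3-fold lower number from compound 2 to compound 3 (0.11 log units; within the scatter) is expected to stay within the scatter. In this assay compound 3 is estimated at 50000 nM (expected range 20000 nM to 100000 nM).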

Compound 3, half-maximal inhibitory concentration: 42300 nM
Beside the measured number, compound 3's estimate is 1.2-fold (0.07 log units) above it; the measured number falls inside the stated range.
By their numbers in this assay, from the lowest: compounds 3, 2 and 1 (each within the scatter of the next, the first and the last beyond it).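

Phenyl to 4-chlorophenyl gives a 1.5-fold lower number from compound 2 to compound 3 (0.18 log units; within the scatter) in this assay and is the only one-place step in the series. On this aromatic carbon, para to a large group, chloro can therefore replace hydrogen without a difference that stands clear of the scatter. Nothing measured accounts for this step or gives any property of the chloro group.

On these data alone, whether an amine, a carboxylic acid or a longer chain at this place would also stay within the scatter remains open. A single step also leaves open how far larger groups here would be tolerated.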